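The source may hold more compounds than are shown below. What is called first, only, known or untested is meant among the compounds shown, and "the series" means these compounds.

Series notes on the step from compound 3 to compound 4. Within the data shown here, compound 3 `COc1cc(N)c(Cl)cc1NC(=O)C1CCN(Cc2ccccc2)CC1` is the only member with a number in a functional assay on the whole organism for antagonist activity, with Mus musculus as the target; on this read-out higher numbers stand for an effect only at larger amounts of compound and lower numbers for an effect already at smaller amounts; compound 3 gives 0.5 mg/kg. Compound 1 `CCCCN1CCC(C(=O)Nc2cc(Cl)c(N)cc2OC)CC1` reaches only a limit, > 10 mg/kg. Compound 2 `COc1cc(N)c(Cl)cc1NC(=O)C1CCN(Cc2cccc(C#N)c2)CC1` likewise reaches only a limit, > 4 mg/kg. The shift an at least 20-fold lower number from compound 1 to compound 3 (1.30 log units; beyond the scatter) rests on (the limit of > 10 mg/kg in this assay, at which 1 of the 3 values shown sits), the shift an at least 8.0-fold lower number from compound 2 to compound 3 (0.90 log units; beyond the scatter) rests on (the limit of > 4 mg/kg in this assay, at which 1 of the 3 values shown sits), and the step that the two limits leave unreadable from compound 1 to compound 2 cannot be sized. Compound 4 `COc1cc(N)c(Cl)cc1NC(=O)C1CCN(Cc2ccc([N+](=O)[O-])cc2)CC1` carries nitro in place of hydrogen on an aromatic carbon. Of the measured steps only an at least 8.0-fold lower number from compound 2 to compound 3 (0.90 log units; beyond the scatter) bears on it: removing cyano from the aromatic carbon lowered the number, so nitro entering on an aromatic carbon is expected to raise it. Compound 4 is therefore expected near 2.5 mg/kg, between 0.7 mg/kg and 8 mg/kg. Compound 4 is expected to show a 5.0-fold higher number from compound 3 to compound 4 (0.70 log units; beyond the scatter) in this assay .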

Compound 4, dose for half-maximal effect: > 4 mg/kg
Compound 4 gave a limit, no number; the forecaster's own chance of this, stated with the estimate: 30%; at least 1.6-fold (0.20 log units) between middle value and limit.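

Phenyl to 4-nitrophenyl, with nitro para to a large group, gives an at least 8.0-fold higher number from compound 3 to compound 4 (0.90 log units; beyond the scatter) in this assay. Together with the 3-cyanophenyl of compound 2, this makes a second substituent on the aromatic ring, at a different place, that leaves the number higher than with the plain phenyl of compound 3. The size of the step rests on a limit, not a number: the limit of > 4 mg/kg in this assay, at which 2 of the 4 values shown sit.

The steps from compound 1 to compound 4 and from compound 2 to compound 4 cannot be read, as each joins two limits. As far as these compounds go, whether methyl, methoxy or an amine at this place would keep the number of compound 3 stays open.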